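This account rests on a few compounds, and the source may have more. Where it says the series, first, only, none or still open, it means among the compounds named here.

Measured compounds in a functional assay on NCI-H292 cells (Homo sapiens) for antiproliferative activity; a lower number here means a stronger inhibitor, a higher number a weaker inhibitor:

compound 1, `O=C(Nc1ccc(Cl)cc1)c1cccc(N2C(=O)N/C(=C\c3ccc(O)cc3)C2=O)c1`: compound 1 gives 125000 nM
compound 2, `O=C(NCc1ccccc1)c1cccc(N2C(=O)N/C(=C\c3ccc(O)cc3)C2=O)c1`: compound 2 gives 23500 nM
compound 3, `O=C(Nc1ccc(Cl)cc1)c1ccc(N2C(=O)N/C(=C\c3ccc(O)cc3)C2=O)cc1`: compound 3 gives only a limit, > 200000 nM

Compounds 1 and 2 share one core; compound 3 carries the same atoms joined differently, and the difference between the two cores is not broken down here. The change from compound 1 to compound 2 is benzyl in place of 4-chlorophenyl on an amide-type nitrogen. In this assay that change gives a 5.3-fold lower number from compound 1 to compound 2 (0.73 log units; beyond the scatter).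

Compound 3 sits at a limit of this assay and not at a number: the limit of > 200000 nM in this assay, at which 1 of the 3 values shown sits. Its value therefore gives no fixed starting point.

Compound 4, `O=C(NCc1ccccc1)c1ccc(N2C(=O)N/C(=C\c3ccc(O)cc3)C2=O)cc1`, is not yet measured. It differs from compound 3 by benzyl in place of 4-chlorophenyl on an amide-type nitrogen, the same kind of change as from compound 1 to compound 2, at the same place on the amide-type nitrogen. The expectation for compound 4 rests on one measured step, namely a 5.3-fold lower number from compound 1 to compound 2 (0.73 log units; beyond the scatter), applied to a starting value that is only a limit. If the step carries over, compound 4 would come to lie at a number inside the range of this assay; if it does not, compound 4 may also remain at the limit. A step like an at least 3.3-fold lower number from compound 3 to compound 4 (0.52 log units; beyond the scatter) is expected, with the limit itself as the reference. For compound 4 in this assay the estimate is 60000 nM, with a range from 20000 nM to 200000 nM.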

Compound 4, half-maximal inhibitory concentration: > 200000 nM
Compound 4 was reported as a limit (the forecaster's own chance of this, stated with the estimate: 45%); at least 3.3-fold (0.52 log units) between middle value and limit.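

In this assay compound 4 gives > 200000 nM as a limit and not a number. Compound 3 also sits at a limit, and no step can be read between compound 3 and compound 4: the limit of > 200000 nM in this assay, at which 2 of the 4 values shown sit.

Still open, from the compounds shown here alone, is how benzyl in place of 4-chlorophenyl on an amide-type nitrogen acts on the core of compound 3, where neither compound has a number.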